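A few compounds are considered here, and "the series" means these few. Any claim that something is new, unique, unknown or untested is made for them only; others in the source may bear on it.

Compound 1 `CCOC(=O)c1c(-c2cccc(Oc3ccccc3)c2)[nH]c2cc(OC)c(Cl)cc2c1=O`: > 21500 nM in an ADME assay on BJ cells (Homo sapiens) for cytotoxicity, read by luminescence, with a stated time of 72 h (a higher number here means that more compound is needed for the effect, a lower number that less compound is needed), a limit.
Compound 2 `CCOC(=O)c1c(-c2cccc(Oc3ccccc3)c2)[nH]c2cc(OC)c(F)cc2c1=O`: > 21500 nM in this assay, also a limit.

Compound 2 therefore has no exact number, and the evidence so far is a single shared limit: the limit of > 21500 nM in this assay, at which 2 of the 2 values shown sit. Compound 3 `CCOC(=O)c1c(-c2cccc(-c3nc(C)c(C)s3)c2)[nH]c2cc(OC)c(F)cc2c1=O` differs from compound 2 by one change, (4,5-dimethyl-1,3-thiazol-2-yl in place of phenoxy on an aromatic carbon). This puts 4,5-dimethyl-1,3-thiazol-2-yl in place of phenoxy on an aromatic carbon. Going by the values given here, the only measured step, a step that the two limits leave unreadable from compound 1 to compound 2, swapped chloro for fluoro at a different place and offers no readable size to carry over. No shift beyond the usual scatter is therefore expected, in either direction. The expected step is a number no higher from compound 2 to compound 3 (the limit leaves the size open). The estimate for compound 3 is 21500 nM, with an expected range of 10000 nM to 30000 nM.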

Compound 3, half-maximal effective concentration: > 21500 nM
Compound 3 ended at the assay's limit (the forecaster's own chance of this, stated with the estimate: 75%); the middle value lies on the limit itself.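

Going by these compounds alone, compound 2 and compound 3 both sit at a limit in this assay, so no step between them can be read. The compounds shown leave open how much of each is needed for the effect: the limit of > 21500 nM in this assay, at which 3 of the 3 values shown sit.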